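Swapping Acetyl for Methylsulfonyl on a Pyrrolidine Nitrogen

A few compounds are considered here, and "the series" means these few. Any claim that something is new, unique, unknown or untested is made for them only; others in the source may bear on it.

Compound 1 `O=C(O)CN(Cc1ccc(Cl)cc1)Cc1ccc([N+](=O)[O-])s1`: in a functional assay on HEK293 cells for agonist activity at nuclear receptor subfamily 1 group D member 1 (Homo sapiens), read by a luciferase reporter, with a stated time of 24 h; on this read-out lower numbers stand for an effect already at smaller amounts and higher numbers for an effect only at larger amounts of compound "not determined" (no result reported)
Compound 2 `O=[N+]([O-])c1ccc(CN(Cc2ccc(Cl)cc2)CC2CCCCC2)s1`: in this assay 7400 nM
Compound 3 `CC(=O)N1CCC(CN(Cc2ccc(Cl)cc2)Cc2ccc([N+](=O)[O-])s2)C1`: in this assay 1600 nM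

Compound 3 stands at the lowest of the two numbers, set apart from compound 2 by a 4.6-fold lower number from compound 2 to compound 3 (0.67 log units; beyond the scatter), while compound 1 contributes no number. Compound 4 `CS(=O)(=O)N1CCC(CN(Cc2ccc(Cl)cc2)Cc2ccc([N+](=O)[O-])s2)C1` differs from compound 3 by methylsulfonyl in place of acetyl on an amine nitrogen in a ring. For the measured compounds named here, no measured step touches this exchange: the one recorded step, from compound 2 to compound 3, concerns a different part of the molecule, so nothing comparable exists to lean on. The expected step of no change at the digits printed from compound 3 to compound 4 (within the scatter) is therefore taken as one that stays within the scatter. For compound 4 the estimate in this assay is 1600 nM, with a range from 500 nM to 5000 nM.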

Compound 4, half-maximal effective concentration: 570 nM
Estimate against measurement, compound 4: 2.8-fold (0.45 log units) above, within the range that was stated.
By their numbers in this assay, from the lowest: compound 4; then compound 3; then compound 2.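

In this assay, for the compounds shown here, methylsulfonyl in place of acetyl on the ring amine nitrogen brings a 2.8-fold lower number from compound 3 to compound 4 (0.45 log units; beyond the scatter) and shows that this position responds to the group it carries, which the earlier compounds could not show. Set against the cyclohexyl group, 1-(methylsulfonyl)pyrrolidin-3-yl brings a 13-fold lower number from compound 2 to compound 4 (1.11 log units; beyond the scatter) and goes further than the acetyl version did. Nothing at hand explains why these numbers differ. Open, on these data alone, is how a larger sulfonyl such as ethylsulfonyl or phenylsulfonyl on the same nitrogen would compare, and equally a plain methyl there.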